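The compounds below may be only part of what the source reports. "The series", "measured", "known", "first", "only" and "open" are said of these compounds alone.

Compound 1 `Cc1nc(Nc2ccc3sc(C(=O)Nc4c(C)cccc4Cl)cc3c2)cc(N2CCCCC2)n1`: 20.6%
Compound 2 `CCN(CC)CCCOc1cc2ncnc(Nc3ccc4sc(C(=O)Nc5c(C)cccc5Cl)cc4c3)c2cc1OC`: 78%
Compound 3 `COc1cc2c(Nc3ccc4sc(C(=O)Nc5c(C)cccc5Cl)cc4c3)ncnc2cc1OCCCN1CCN(C)CC1`: 76%

All three were tested in a functional assay on U-937 cells (Homo sapiens) for inhibition, read by MTT assay and WST assay, with a stated time of 72 h, tested at 10 uM; a higher number here means more inhibition of growth at the concentration tested, a lower number less inhibition of growth. Compound 1 gives 20.6%, the lowest of the three numbers; compound 2 gives 78% and compound 3 gives 76%, each beyond the scatter above compound 1. Compound 4 `CCN1CCN(c2cc(Nc3ccc4sc(C(=O)Nc5c(C)cccc5Cl)cc4c3)nc(C)n2)CC1` has not yet been measured. It differs from compound 1 in one place: 4-ethylpiperazin-1-yl in place of piperidin-1-yl on an aromatic carbon. Among the measured compounds shown here, the only measured step that changes a single group runs between compound 2 and compound 3, where a 4-methylpiperazin-1-yl group replaces diethylamino on a saturated chain carbon, three bonds along the chain from an oxygen on an aromatic ring; that step was a number 2 percentage points lower from compound 2 to compound 3 (within the scatter). It bears only loosely on the present change, since there the amine sits on a chain rather than on an aromatic carbon, but it gives no sign that swapping one saturated nitrogen ring for a piperazine moves the number. The large gap between compound 1 and compounds 2 and 3 comes with a different shared core, not with this group. No step beyond the scatter is therefore expected from compound 1 to compound 4 in this assay, an expected a number 4.4 percentage points higher from compound 1 to compound 4 (within the scatter). Compound 4 is estimated at 25%, within a range from 5% to 50%.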

Compound 4, percent growth inhibition at one concentration: 46.5%
Compound 4: the middle estimate sits 21.5 percentage points below what was measured; measured number inside the range.
By their numbers in this assay, from the lowest: compound 1; then compound 4; then compounds 3 and 2 (each within the scatter of the next).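

In this assay, replacing piperidin-1-yl with 4-ethylpiperazin-1-yl on this aromatic carbon next to the ring nitrogen gives a number 25.9 percentage points higher from compound 1 to compound 4 (beyond the scatter) and so shows that the number responds to the group at this place. Among the compounds shown here, the only earlier swap of one amine group for another, on a saturated chain, gave a number 2 percentage points lower from compound 2 to compound 3 (within the scatter) and offered no sign of such a response. Nothing available explains the rise.

The entering group brings both a second ring nitrogen and an ethyl group, and the compounds shown cannot separate the two; piperazin-1-yl with no ethyl group, or morpholin-4-yl, at this carbon would address that. On these data alone, whether an open-chain amine such as diethylamino would behave like either ring at this carbon also stays open.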